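Thiophen-2-yl to 1,3-thiazol-5-yl: working notes on the series

The compounds below may be only part of what the source reports. "The series", "measured", "known", "first", "only" and "open" are said of these compounds alone.

- compound 1 `CC(C)n1ncc2c(C(=O)Nc3ccccc3F)cc(-c3ccccn3)nc21`: 100000 nM
- compound 2 `CC(C)n1ncc2c(C(=O)Nc3ccccc3F)cc(-c3cccnc3)nc21`: 50000 nM
- compound 3 `CC(C)n1ncc2c(C(=O)Nc3ccccc3F)cc(-c3cccs3)nc21`: 50000 nM

In an ADME assay on LLC-MK2 cells (Macaca mulatta) for cytotoxicity, read by spectrophotometry and crystal violet staining, with a stated time of 4 days (on this read-out lower numbers stand for higher toxicity in this test and higher numbers for lower toxicity in this test), compound 3 gives 50000 nM, level with compound 2 at the digits shown. All three compounds lie within the scatter of one another.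

Compound 4 `CC(C)n1ncc2c(C(=O)Nc3ccccc3F)cc(-c3cncs3)nc21` has 1,3-thiazol-5-yl in place of thiophen-2-yl on an aromatic carbon, with the rest of the structure unchanged: 1,3-thiazol-5-yl in place of thiophen-2-yl on an aromatic carbon.

The measured steps bearing on this change are swaps of the group at the same carbon: a 2.0-fold lower number from compound 1 to compound 2 (0.30 log units; within the scatter), a 2.0-fold lower number from compound 1 to compound 3 (0.30 log units; within the scatter) and no change at the digits printed from compound 2 to compound 3 (within the scatter). None goes beyond the scatter. Going by the values given here, no compound with 1,3-thiazol-5-yl has been measured, so the swaps of other aromatic rings are the only guide. No step beyond the scatter is therefore expected in this assay, and no direction is favoured. The expected step is a 1.2-fold higher number from compound 3 to compound 4 (0.08 log units; within the scatter). For compound 4 the estimated value is 60000 nM, with an expected range from 25000 nM to 120000 nM.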

Compound 4, half-maximal cytotoxic concentration: 100000 nM
Estimate against measurement, compound 4: 1.7-fold (0.22 log units) below, and the stated range covers the measured number.
By their numbers in this assay, from the lowest: compounds 2, 3, 1 and 4 (each within the scatter of the next).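

With 1,3-thiazol-5-yl on this aromatic carbon, a five-membered aromatic ring with 2 hetero atoms joins the rings that stay within the scatter in this assay: the swap for thiophen-2-yl gives a 2.0-fold higher number from compound 3 to compound 4 (0.30 log units; within the scatter) and the swap for pyridin-3-yl gives a 2.0-fold higher number from compound 2 to compound 4 (0.30 log units; within the scatter) in this series. Against pyridin-2-yl the swap gives no change at the digits printed from compound 1 to compound 4 (within the scatter), so all four aromatic rings at this carbon now lie within the scatter of one another, and adding a hetero atom to the five-membered ring produces no step beyond it. Nothing available accounts for these numbers.

Still open, on these data alone, is whether an amine, a carboxylic acid or a longer chain at this carbon would give a step beyond the scatter. The compounds shown also say nothing about changes elsewhere on the shared core.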